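A few compounds are considered here, and "the series" means these few. Any claim that something is new, unique, unknown or untested is made for them only; others in the source may bear on it.

Measured compounds:
- Compound 1, `CC(C)(C)OC(=O)N1CCC(O[C@H]2CC[C@H](Oc3cnc(S(C)(=O)=O)cn3)CC2)CC1`, gives 64 nM in a functional assay on isolated protein for agonist activity at Glucose-dependent insulinotropic receptor (Rattus norvegicus), read by HTRF and cAMP accumulation; a lower number here means that less compound is needed, a higher number that more compound is needed for the effect.
- Compound 2, `CC(C)S(=O)(=O)c1cnc(O[C@H]2CC[C@H](OC3CCN(C(=O)OC(C)(C)C)CC3)CC2)cn1`, gives 54 nM in this assay.

Compound 1 stands as the highest of these two numbers, but its nearest neighbour, compound 2, sits within the scatter of it: the step of a 1.2-fold lower number from compound 1 to compound 2 (0.07 log units; within the scatter) is too small to count as a real change. Compound 3, `CC(F)Cc1nc(CN2CCC(O[C@H]3CC[C@H](Oc4cnc(S(C)(=O)=O)cn4)CC3)CC2)no1`, has not been measured. It differs from compound 1 as follows: (5-(2-fluoropropyl)-1,2,4-oxadiazol-3-yl)methyl in place of tert-butoxycarbonyl on an amine nitrogen in a ring. Within the data shown here, the one measured step, from compound 1 to compound 2, concerns the group on the sulfonyl sulfur at the far end of the molecule, not the amine nitrogen in a ring, so it gives no direct guide for the present change. With nothing in the data to lean on, the expectation for compound 3 rests on the size of the change itself and carries a wide range. Compound 3 is expected to give about 25 nM in this assay, somewhere between 5 nM and 120 nM. This estimate means a step of a 2.6-fold lower number from compound 1 to compound 3 (0.41 log units; beyond the scatter), expected as a moderate move toward a lower number, but it could also fall within the scatter of compound 1.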

Compound 3, half-maximal effective concentration: 267 nM
The estimate for compound 3 lay 11-fold (1.03 log units) below the measured number; measured number above the stated range.
By their numbers in this assay, from the lowest: compounds 2 and 1 (each within the scatter of the next); then compound 3.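

Among these compounds, replacing tert-butoxycarbonyl with (5-(2-fluoropropyl)-1,2,4-oxadiazol-3-yl)methyl on the amine nitrogen in a ring gives a 4.2-fold higher number from compound 1 to compound 3 (0.62 log units; beyond the scatter) in this assay, the first step here beyond the scatter, so the number does respond to a change at this position. This single swap alters several things at once: the entering group has more heavy atoms, brings a five-membered aromatic ring, and has no double bond outside an aromatic ring, so the step cannot be assigned to any one of these. Nothing available explains the higher number.

The compounds shown do not separate the contribution of the ring from that of the 2-fluoropropyl group; a plain propyl chain on the same ring would test the fluorine alone. Going by these compounds, whether a smaller group such as ethoxycarbonyl would keep the number of compound 1 also remains open.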